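Chlorophenyl regioisomers on a shared core: working notes

This account rests on a few compounds, and the source may have more. Where it says the series, first, only, none or still open, it means among the compounds named here.

The series rests on one core, first seen in compound 1 `C#CCSc1nc(Nc2cccc(C(F)(F)F)c2)c(C#N)c(-c2ccccc2)n1`. In a functional assay on MGC-803 cells (Homo sapiens) for inhibition, read by MTT assay, with a stated time of 72 h (on this read-out lower numbers stand for stronger inhibition and higher numbers for weaker inhibition), compound 1 gives > 128000 nM, which is a limit of the assay and not a number. Compound 2 `C#CCSc1nc(Nc2ccc(Cl)cc2)c(C#N)c(-c2ccccc2)n1` carries the 4-chlorophenyl group on the ring nitrogen. In this assay compound 2 gives > 128000 nM, again a limit rather than a measured number. Among the measured compounds shown here, compound 2 thus stands where every value so far stands, as summarised by the limit of > 128000 nM in this assay, at which 2 of the 2 values shown sit. Compound 3 `C#CCSc1nc(Nc2cccc(Cl)c2)c(C#N)c(-c2ccccc2)n1` is the next candidate; the change is 3-chlorophenyl in place of 4-chlorophenyl on a nitrogen on an aromatic ring, the two having the same atoms joined differently. For the measured compounds named here, no step between measured compounds exists to calibrate such a move, so no shift beyond the usual scatter is expected in either direction, and the expected step is a step that the limit leaves unreadable from compound 2 to compound 3. For compound 3 the estimate is 160000 nM, spanning 40000 nM to 600000 nM, most probably returned once more as a limit.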

Compound 3, half-maximal inhibitory concentration: > 128000 nM
Compound 3: a limit, no number; the forecaster's own chance of this, stated with the estimate: 75%; the middle value lies beyond the limit too.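

In this assay, among the compounds shown here, compound 3 gives > 128000 nM, again a limit and not a number, and no step from compound 1 or compound 2 to compound 3 can be read. The compounds shown leave open whether any group on the shared core gives a measurable value: the limit of > 128000 nM in this assay, at which 3 of the 3 values shown sit.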